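Cyclohexyl for isobutyl on a sulfur

The compounds below may be only part of what the source reports. "The series", "measured", "known", "first", "only" and "open" are said of these compounds alone.

Of the compounds shown here, three have been measured in a functional assay on MT4 cells (Homo sapiens) for cytotoxicity; a higher number here means that more compound is tolerated, a lower number that less compound is tolerated: compound 1 `CSc1nc(O)cc(C(C)c2c(F)cccc2F)n1`, compound 2 `CCC(c1cc(O)nc(SC2CCCCC2)n1)c1c(F)cccc1F` and compound 3 `CC(C)CSc1nc(O)cc(C(C)c2c(F)cccc2F)n1`. In this assay compound 1 gives 20800 nM. Compound 2 gives > 200000 nM, which is a limit of the assay and not a number. Compound 3 gives > 200000 nM, which is also only a limit. Compound 3 therefore has no exact value and stands at the limit of > 200000 nM in this assay, at which 2 of the 3 values shown sit.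

The next compound is compound 4 `CC(c1cc(O)nc(SC2CCCCC2)n1)c1c(F)cccc1F`. It keeps the rest of compound 3 and carries cyclohexyl in place of isobutyl on a sulfur.

Within the data shown here, one measured step bears directly on this position. It is an at least 9.6-fold higher number from compound 1 to compound 3 (0.98 log units; beyond the scatter), a change in the group on the same sulfur, and it lies beyond the scatter. Compound 2 also carries cyclohexyl on a sulfur, although the rest of it is not identical to compound 4. The value of compound 2 is > 200000 nM, which is a limit. Taking compound 2 as the closest guide, no large step is expected in this assay, and any change should be towards a lower number. The estimated change is an at least 1.3-fold lower number from compound 3 to compound 4 (0.12 log units; that floor lies within the scatter). For compound 4 the estimated value is 150000 nM, with an expected range of 50000 nM to 250000 nM.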

Compound 4, half-maximal cytotoxic concentration: > 200000 nM
Compound 4 ended at the assay's limit (the forecaster's own chance of this, stated with the estimate: 60%); at least 1.3-fold (0.12 log units) between middle value and limit.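

In this assay, among these compounds, cyclohexyl in place of methyl on the sulfur gives an at least 9.6-fold higher number from compound 1 to compound 4 (0.98 log units; beyond the scatter), so the higher number seen with isobutyl also appears with a ring on this sulfur, and compound 1 remains the only compound here with a lower tolerated concentration. The steps from compound 3 to compound 4 and from compound 2 to compound 4 cannot be read, as both ends of each step are limits of the assay. Isobutyl and cyclohexyl on the sulfur therefore cannot be ranked against each other, and neither can hydrogen and methyl on the chain carbon, as most of the series rests at one ceiling: the limit of > 200000 nM in this assay, at which 3 of the 4 values shown sit.

As far as these compounds go, compound 1 alone has an exact value, 20800 nM, so how much compound the other three tolerate remains unknown. Also open, from the compounds shown here alone, is how the number responds to other groups on this sulfur, such as ethyl, benzyl or a chain ending in an amine, and whether any of them would come back from the limit to a value that can be read.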